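Replacing Methoxyphenyl by Methylphenyl on a Ring Nitrogen

This account rests on a few compounds, and the source may have more. Where it says the series, first, only, none or still open, it means among the compounds named here.

Measured compounds:
compound 1, `CCCc1nc(-c2ccccc2)c(CNCCN2CCN(c3ccccc3F)CC2)o1`, giving 46.5%
compound 2, `CCCc1nc(-c2ccccc2)c(CNCCCN2CCN(c3ccc(OC)cc3)CC2)o1`, giving 42.1%

Of the compounds shown here, two have been measured in an assay on HEK293 cells for inhibition of Voltage-dependent T-type calcium channel subunit alpha-1G (Homo sapiens), read by fluorescence, tested at 10 uM; a lower number here means less inhibition, a higher number more inhibition at the concentration tested (going by the name of the read-out). Compound 1 gives 46.5%, and compound 2 gives 42.1%. Compound 2 carries the lowest of the two numbers, but its nearest neighbour, compound 1, sits within the usual scatter of it, so the two values show no real separation. Within the data shown here, the two compounds differ in more than one place, so no single step between them can be read.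

Compound 3, `CCCc1nc(-c2ccccc2)c(CNCCCN2CCN(c3ccccc3C)CC2)o1`, is not yet measured. It differs from compound 2 in one place: 2-methylphenyl in place of 4-methoxyphenyl on an amine nitrogen in a ring. Among the measured compounds shown here, with no step between measured compounds available, the expectation rests on the two values alone, which lie close together; the change is therefore expected to produce either no step beyond the scatter in this assay or a small one upward. Compound 3 is accordingly estimated at 48%, with a range from 30% to 66%, which corresponds to an expected step of a number 5.9 percentage points higher from compound 2 to compound 3 (within the scatter).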

Compound 3, a percentage reported as inhibition, at one concentration (the size of the read-out at that concentration, not a potency): 54.5%
Estimate against measurement, compound 3: 6.5 percentage points below; the measured number falls inside the stated range.
By their numbers in this assay, from the lowest: compounds 2, 1 and 3 (each within the scatter of the next, the first and the last beyond it).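

In this assay, the group on the amine nitrogen in the ring proves able to move the read-out: 2-methylphenyl in place of 4-methoxyphenyl gives a number 12.4 percentage points higher from compound 2 to compound 3 (beyond the scatter), a modest step. Among these compounds, this is the first step that can be read, since compound 2 and compound 3 differ in this one place while sharing the rest of their structure. The exchange removes the single hydrogen-bond acceptor of the leaving group and leaves the six-membered aromatic ring of carbon in place, but nothing shown connects either feature to the higher number, and no measurement on hand accounts for the step.

The change alters both the substituent and where it stands on the phenyl ring, so the step cannot be assigned to either alone; 2-methoxyphenyl and 4-methylphenyl groups on this nitrogen would be the compounds to separate the two. As far as these compounds go, the read-out also comes from one concentration, so how compound 2 and compound 3 compare in potency stays open.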